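Nitro in place of chloro: cell tolerance notes

The compounds below may be only part of what the source reports. "The series", "measured", "known", "first", "only" and "open" are said of these compounds alone.

Measured so far in an ADME assay on MT4 cells (Homo sapiens) for cytotoxicity, read by MTT assay, with a stated time of 4 days; a lower number here means that less compound is tolerated, a higher number that more compound is tolerated:
compound 1, `C/C(=N\NC(=O)COc1cccc2ccccc12)c1ccc([N+](=O)[O-])cc1`: compound 1 gives 89.3 ug/mL
compound 2, `C/C(=N\NC(=O)COc1cccc2ccccc12)c1ccc(Cl)cc1`: compound 2 gives 4.07 ug/mL
compound 3, `O=C(COc1cccc2ccccc12)N/N=C/c1ccccc1Cl`: compound 3 gives 56.2 ug/mL

Compounds 1 and 2 share one core and differ by nitro in place of chloro on an aromatic carbon. That change gives a 22-fold higher number from compound 2 to compound 1 (1.34 log units; beyond the scatter), so the nitro compound is tolerated at a clearly higher concentration than its chloro partner.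

Compound 3 has a different core from compound 2; the difference between the two cores is not broken down here. Its value in this assay stands closest to compound 1, within the scatter, and well apart from compound 2.

Compound 4, `O=C(COc1cccc2ccccc12)N/N=C/c1ccccc1[N+](=O)[O-]`, has not been measured. It differs from compound 3 by nitro in place of chloro on an aromatic carbon. This is the same kind of change as that from compound 2 to compound 1, not the same one: there the place is para to a large group, here it is ortho to a large group, and the core is that of compound 3.

Given that the one measured instance of this change, a 22-fold higher number from compound 2 to compound 1 (1.34 log units; beyond the scatter), ran toward a higher number, compound 4 is expected to sit higher than compound 3 as well, by an estimated 2.0-fold higher number from compound 3 to compound 4 (0.29 log units; within the scatter), though the starting number of compound 3 is already high and the assay may report only a limit. The estimate for compound 4 in this assay is 110 ug/mL, between 45 ug/mL and 250 ug/mL.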

Compound 4, half-maximal cytotoxic concentration in the MT4 assay: 12.2 ug/mL
Estimate against measurement, compound 4: 9.0-fold (0.96 log units) above; measured number below the stated range.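

In the MT4 assay, nitro in place of chloro gives a 4.6-fold lower number from compound 3 to compound 4 (0.66 log units; beyond the scatter), so on this core the nitro compound is tolerated at a lower concentration than its chloro partner, and the direction of the step reverses between the two cores: the same change on two cores in the MT4 assay, a 22-fold higher number (1.34 log units; beyond the scatter) from compound 2 to compound 1 and a 4.6-fold lower number (0.66 log units; beyond the scatter) from compound 3 to compound 4, 100-fold (2.00 log units) apart, beyond the scatter of two such steps This shows that in this series the change does not carry from the core of compound 1 to the core of compound 3 with a fixed direction or size, but it does not show what sets the direction, as the two pairs differ both in core and in the place of the change. In a physicochemical assay for lipophilicity, measured as octanol-water partition (a lower number here means a more polar compound, a higher number a more lipophilic compound), compound 3 gives 4.54 and compound 4 gives 3.97, yet this single pair does not show that the lower partition coefficient accounts for the lower number in the cell assay: the measured partition coefficient of compound 3, 4.54, and of compound 4, 3.97, a number 0.57 log units lower (beyond the scatter)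

Going by these compounds, it remains open whether the reversal follows the core or the place, and only a nitro and chloro pair that shares the core of compound 1 with the group ortho to a large group, or the reverse combination, could separate the two. On these data alone, it also remains open whether a different group at that place, such as an amine or a carboxylic acid, would track nitro or chloro in the MT4 assay.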